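Amino for hydrogen on the shared core of two analogues

A few compounds are considered here, and "the series" means these few. Any claim that something is new, unique, unknown or untested is made for them only; others in the source may bear on it.

The study concerns four compounds built on one bicyclic core and differing in two places. Compound 1 `ClCc1ccc(Cn2cnc3c(Cl)ncnc32)cc1` and compound 2 `Nc1nc(Cl)c2ncn(Cc3ccc(CCl)cc3)c2n1` form the first pair; compound 3 `ClCc1ccccc1Cn1cnc2c(Cl)ncnc21` and compound 4 `Nc1nc(Cl)c2ncn(Cc3ccccc3CCl)c2n1` form the second. Compound 3 and compound 1 have the same atoms, joined differently; how the two cores differ is not broken down here.

In a functional assay on SK-MEL-5 cells (Homo sapiens) for cytotoxicity, read by sulforhodamine B assay, with a stated time of 48 h (a lower number here means a stronger inhibitor of growth, a higher number a weaker inhibitor of growth), compound 1 gives 3230 nM, while compound 2 gives 15500 nM. The change from compound 1 to compound 2 is amino in place of hydrogen on an aromatic carbon, and it made a 4.8-fold higher number from compound 1 to compound 2 (0.68 log units; beyond the scatter). Compound 3 gives 1410 nM in this assay, the lowest of the three measured numbers, with compound 1 nearest and compound 2 furthest from it.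

Compound 4 has not yet been measured. It differs from compound 3 by amino in place of hydrogen on an aromatic carbon, which is the same change at the same place as that from compound 1 to compound 2. Because compound 2 moved by a 4.8-fold higher number from compound 1 to compound 2 (0.68 log units; beyond the scatter) from compound 1, compound 4 is expected to show a step of about a 4.8-fold higher number from compound 3 to compound 4 (0.68 log units; beyond the scatter) from compound 3, with the size resting on that single earlier pair and on the knowledge that the rearranged core of compound 3 may not answer identically. Compound 4 is therefore estimated at 6800 nM, with a plausible range from 3000 nM to 15000 nM.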

Compound 4, concentration for 50% growth inhibition: 8510 nM
Beside the measured number, compound 4's estimate is 1.3-fold (0.10 log units) below it; the measured number falls inside the stated range.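

In this assay, amino in place of hydrogen on the aromatic carbon between two ring nitrogen atoms gave a 6.0-fold higher number from compound 3 to compound 4 (0.78 log units; beyond the scatter), a step in the same direction as the earlier one, a 4.8-fold higher number from compound 1 to compound 2 (0.68 log units; beyond the scatter). Set side by side, the two steps cannot be told apart, so within these two pairs the change carried from one core to the other with both its direction and its size preserved: the same change on two cores in this assay, a 4.8-fold higher number (0.68 log units; beyond the scatter) from compound 1 to compound 2 and a 6.0-fold higher number (0.78 log units; beyond the scatter) from compound 3 to compound 4, 1.3-fold (0.10 log units) apart, within the scatter of two such steps. Going by these compounds alone, this agreement rests on only two pairs in a single cell assay, and it shows neither why the amino group goes with a weaker inhibition of growth nor whether a step of this size would hold on any other core or in any other assay.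

The compounds shown leave open how other groups on that same aromatic carbon would compare with hydrogen and amino, for example a methyl group, a hydroxyl group or a dimethylamino group. They also leave open whether the step would survive if the chloro group were exchanged for an amine, or if the chloromethyl group were exchanged for a plain methyl group or a longer chain.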